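This account rests on a few compounds, and the source may have more. Where it says the series, first, only, none or still open, it means among the compounds named here.

Measured compounds:
compound 1 `Nc1ccccc1NC(=O)c1ccc(Cn2cnc3c(Nc4ccccc4)nc(Cl)nc32)cc1`: 83.5%
compound 2 `Nc1ccccc1NC(=O)/C=C/c1ccc(Cn2cnc3c(NC4CCCCC4)nc(Cl)nc32)cc1`: 18.7%

Of the compounds shown here, two have been measured in a functional assay on HCT-116 cells (Homo sapiens) for antiproliferative activity, read by CCK-8 assay, with a stated time of 72 h, tested at 8 uM; a lower number here means a weaker effect, a higher number a stronger effect of the compound at the concentration tested. Compound 1 gives 83.5%, the higher of the two numbers. Compound 2 differs from compound 1 in several places. Compound 2 gives 18.7%, a much lower reading that lies well beyond the usual scatter, so the two compounds are clearly set apart. Within the data shown here, no pair of measured compounds differs in only one place, so no single step has been measured directly.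

Compound 3 `CN1CCN(c2nc(Cl)nc3c2ncn3Cc2ccc(C(=O)Nc3ccccc3N)cc2)CC1` has not yet been measured. It keeps the core of compound 1 and changes one group on it: 4-methylpiperazin-1-yl in place of anilino on an aromatic carbon. Among the measured compounds shown here, the measured data give no step of this kind, so the expected size of the change in this assay rests only on the high reading of compound 1 and the fact that a large loss is possible on this core, as compound 2 shows. A moderate drop, or none beyond the scatter, seems most likely; the step is expected to be a number 23.5 percentage points lower from compound 1 to compound 3 (beyond the scatter). Compound 3 is estimated to give 60%, within a range from 30% to 85%.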

Compound 3, a percentage reported as inhibition, at one concentration (the size of the read-out at that concentration, not a potency): 72.8%
Beside the measured number, compound 3's estimate is 12.8 percentage points below it; measured number inside the range.
By their numbers in this assay, from the lowest: compound 2; then compound 3; then compound 1.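

In this assay, among these compounds, putting 4-methylpiperazin-1-yl in place of anilino on this aromatic carbon gives the first single-place step on the core of compound 1, and it is a modest one: a number 10.7 percentage points lower from compound 1 to compound 3 (beyond the scatter). The entering group has one six-membered non-aromatic ring with 2 hetero atoms and 0 hydrogen-bond donors, whereas anilino has one six-membered aromatic ring of carbon only and 1 hydrogen-bond donor, yet compound 3 still gives 72.8%. A strong reading at this position therefore does not depend on keeping the anilino group, although the swap does carry a measurable cost, and no measurement available here explains that cost.

Still open, as far as these compounds go, is how other groups would behave on this carbon: a morpholin-4-yl ring, a piperazin-1-yl ring without its methyl, or a small open-chain dimethylamino group could show which parts of the entering group matter. From the compounds shown here alone, each reading also reflects a single concentration rather than a potency, so how far compound 1 and compound 3 differ in potency remains unknown.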